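From piperidin-4-yl to cyclobutylmethyl on an amide-type nitrogen

A few compounds are considered here, and "the series" means these few. Any claim that something is new, unique, unknown or untested is made for them only; others in the source may bear on it.

In a functional assay on Shh Light II cells (Mus musculus) for inhibition, read by a luciferase reporter (on this read-out lower numbers stand for stronger inhibition and higher numbers for weaker inhibition), compound 3 (`O=C(NC1CCNCC1)N1CCC(c2nc(-c3ccc4ccccc4n3)no2)CC1`) gives 2500 nM as its result. Compound 1 (`C[C@@H]1C[C@H](c2nc(-c3ccc4ccccc4n3)no2)CCN1C(=O)Nc1ccccc1Cl`) gives 2400 nM and the two cannot be told apart, since their gap lies within the usual scatter of repeat measurements. Compound 2 (`O=C(NC1CCCCC1)N1CCN(c2nc(-c3ccc4ccccc4n3)no2)CC1`) gives 53 nM in this test, and that gap to compound 3 lies well beyond the scatter, so compound 3 sits among the weaker results seen so far.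

The next compound, compound 4 (`O=C(NCC1CCC1)N1CCC(c2nc(-c3ccc4ccccc4n3)no2)CC1`), keeps the rest of compound 3 and changes one group: cyclobutylmethyl in place of piperidin-4-yl on an amide-type nitrogen. The entering group has no hetero atom in its ring, while the leaving group has one. Among the compounds with values here, no measured pair differs in only one place, so nothing here shows directly what such a swap does. Within the data shown here, the one loose hint is compound 2 at 53 nM. It shows that much lower numbers are reachable among these compounds, although it differs from compound 3 in more than one place.

A moderate gain in inhibition is therefore expected, beyond the scatter but with wide uncertainty. The estimate amounts to an expected 6.3-fold lower number from compound 3 to compound 4 (0.80 log units; beyond the scatter) in this assay on this reasoning. Compound 4 is estimated at 400 nM with an expected range from 80 nM to 2000 nM in this test.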

Compound 4, half-maximal inhibitory concentration: 410 nM
Compound 4: the middle estimate sits 1.0-fold (0.01 log units) below what was measured, within the range that was stated.
By their numbers in this assay, from the lowest: compound 2; then compound 4; then compounds 1 and 3 (each within the scatter of the next).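

In this assay, within the data shown here, putting cyclobutylmethyl in place of piperidin-4-yl on the amide-type nitrogen gives a 6.1-fold lower number from compound 3 to compound 4 (0.79 log units; beyond the scatter), and this is the first change that can be read on its own, with the rest of the molecule held constant. It shows that this position accepts a group with a ring of carbon only and no hydrogen-bond donors or acceptors, and that inhibition gets stronger with that group, so the ring nitrogen of piperidin-4-yl is not required for inhibition at this position. Nothing measured here explains why the number falls, so the gain stands as an observation without a known cause.

This single step changes several things at once: the ring shrinks from six-membered to four-membered, the hetero atom goes, and the group's total count of heavy atoms changes, so the result cannot say which of these matters. Whether the ring nitrogen alone accounts for the gain remains open, and a cyclopentyl group, a tetrahydropyran-4-yl group or an open chain such as n-pentyl on the same nitrogen would help to pull these features apart.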